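The source may hold more compounds than are shown below. What is called first, only, known or untested is meant among the compounds shown, and "the series" means these compounds.

Compound 1 `O=C(/C=C/c1ccccc1)OCC1COCCOCCOCCOCCOCCO1`: 57000 nM in a functional assay on HBL-100 cells (Homo sapiens) for inhibition, read by sulforhodamine B assay, with a stated time of 48 h; a lower number here means a stronger inhibitor of growth, a higher number a weaker inhibitor of growth
Compound 2 `O=C(CCCCC1CCCCC1)OCC1COCCOCCOCCOCCOCCO1`: 72000 nM in this assay
Compound 3 `CC/C=C/CC(=O)OCC1COCCOCCOCCOCCOCCO1`: > 100000 nM in this assay, which is a limit of the assay and not a number

Compound 3 stands at the weak end of the three measured compounds, and its value is only a limit (the limit of > 100000 nM in this assay, at which 1 of the 3 values shown sits). The two steps that reach compound 3, an at least 1.7-fold higher number from compound 1 to compound 3 (0.24 log units; that floor lies within the scatter) and an at least 1.3-fold higher number from compound 2 to compound 3 (0.14 log units; that floor lies within the scatter), are floors that lie within the scatter, so they separate compound 3 from compound 1 and compound 2 only loosely. Compound 4 `O=C(OCC1COCCOCCOCCOCCOCCO1)c1cccnc1` differs from compound 3 by pyridin-3-yl in place of pent-2-en-1-yl on a carbonyl carbon. Among the compounds with values here, no measured step exchanges a chain for an aromatic ring on this carbonyl carbon, so the measured steps give no direction. The step expected is a number no higher from compound 3 to compound 4 (the limit leaves the size open), that is, none beyond the scatter. Compound 4 is therefore estimated at 100000 nM, in a range from 40000 nM to 250000 nM, with a real chance that this assay again reports only a limit.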

Compound 4, concentration for 50% growth inhibition: > 100000 nM
Compound 4 was reported as a limit (the forecaster's own chance of this, stated with the estimate: 50%); the middle value sits exactly at the limit.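

In this assay compound 4 gives > 100000 nM, a limit of the assay and not a number. The readable comparisons are an at least 1.3-fold higher number from compound 2 to compound 4 (0.14 log units; that floor lies within the scatter) and an at least 1.7-fold higher number from compound 1 to compound 4 (0.24 log units; that floor lies within the scatter), while the step from compound 3 cannot be read. So pyridin-3-yl on this carbonyl carbon gives no readable value, and a second compound now rests at the limit: the limit of > 100000 nM in this assay, at which 2 of the 4 values shown sit.

As far as these compounds go, whether an amine or a carboxylic acid on this carbonyl carbon would give a value clear of the limit stays open.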